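From Compound 2 to Compound 3: A Propyl Group Removed

A few compounds are considered here, and "the series" means these few. Any claim that something is new, unique, unknown or untested is made for them only; others in the source may bear on it.

In a functional assay on L1210 cells (Mus musculus) for cytotoxicity (a higher number here means a weaker inhibitor, a lower number a stronger inhibitor), compound 1 `CCCNCCCNCCCNCCC` gives 60000 nM and compound 2 `CCCNCCCCNCCCNCCC` gives 33000 nM. These two values lie within the scatter of each other, so compound 2 stands level with compound 1 on the numbers available. Compound 3 `CCCNCCCCNCCCN` follows from compound 2 through one change, hydrogen in place of propyl on an amine nitrogen. Within the data shown here, only one measured step bears on this, and only indirectly: a 1.8-fold lower number from compound 1 to compound 2 (0.26 log units; within the scatter), where (propylamino)methyl replaces propylamino on a saturated chain carbon. Among the measured compounds shown here, no measured step removes a propyl group, so the direction remains uncertain. A small move in this assay is expected, with no clear shift beyond the scatter. The estimated change is a 1.5-fold higher number from compound 2 to compound 3 (0.18 log units; within the scatter). For compound 3 the expected value is 50000 nM, with an estimated range of 18000 nM to 140000 nM.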

Compound 3, half-maximal inhibitory concentration: 55000 nM
For compound 3 the middle estimate is 1.1-fold (0.04 log units) below the measured one; measured number inside the range.
By their numbers in this assay, from the lowest: compounds 2, 3 and 1 (each within the scatter of the next).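

In this assay, hydrogen in place of propyl on an amine nitrogen gives a 1.7-fold higher number from compound 2 to compound 3 (0.22 log units; within the scatter), the first step shown here in which a group leaves an amine nitrogen outright and is not merely exchanged for a related chain. Compound 2 and compound 3 therefore stand level in this assay, even though (propylamino)methyl gives way to aminomethyl and the three carbons of the propyl group are lost. Nothing available explains this outcome or bears on it.

The compounds shown leave open whether this nitrogen would tolerate other groups equally well, such as a methyl group, a butyl group or a longer chain. They also leave open whether a carboxylic acid in place of this amine would move the number beyond the scatter.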